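Branching the Nitrogen Substituent: From Compound 3 to Compound 4

The source may hold more compounds than are shown below. What is called first, only, known or untested is meant among the compounds shown, and "the series" means these compounds.

Measured compounds:
compound 1 `C/C(=C\C(=O)Nc1ccccc1OCCCC(=O)O)c1ccc2c(ccn2C)c1`: 780 nM
compound 2 `CCCCCn1ccc2cc(/C(C)=C/C(=O)Nc3ccccc3OCCCC(=O)O)ccc21`: 23 nM
compound 3 `C/C(=C\C(=O)Nc1ccccc1OCCCC(=O)O)c1ccc2c(ccn2Cc2cccc(C)c2)c1`: 250 nM

In an assay on Prostate gland for inhibition of steroid 5-alpha-reductase (Rattus norvegicus) (on this read-out lower numbers stand for stronger inhibition and higher numbers for weaker inhibition), compound 3 gives 250 nM, the second highest of the three numbers. The step of a 3.1-fold lower number from compound 1 to compound 3 (0.49 log units; beyond the scatter) places it nearest to compound 1, while an 11-fold higher number from compound 2 to compound 3 (1.04 log units; beyond the scatter) separates it furthest from compound 2.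

Compound 4 `C/C(=C\C(=O)Nc1ccccc1OCCCC(=O)O)c1ccc2c(ccn2C(c2ccccc2)C(C)C)c1` differs from compound 3 only at the nitrogen: 2-methyl-1-phenylpropyl in place of 3-methylbenzyl on an aromatic nitrogen. For the measured compounds named here, the steps that bear on this are a 34-fold lower number from compound 1 to compound 2 (1.53 log units; beyond the scatter) and an 11-fold higher number from compound 2 to compound 3 (1.04 log units; beyond the scatter), which together show that a saturated chain on this position gave a far lower number than a ring-bearing group. Compound 4 keeps the ring but adds branched saturated carbon, so a modest move toward a lower number is expected, a 2.1-fold lower number from compound 3 to compound 4 (0.32 log units; beyond the scatter). Compound 4 is therefore estimated at 120 nM, within 40 nM to 400 nM.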

Compound 4, half-maximal inhibitory concentration: 25 nM
Compound 4: the middle estimate sits 4.8-fold (0.68 log units) above what was measured; measured number below the stated range.
By their numbers in this assay, from the lowest: compounds 2 and 4 (each within the scatter of the next); then compound 3; then compound 1.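

In this assay, a ring on the substituent at the aromatic nitrogen does not preclude a low number: 2-methyl-1-phenylpropyl gives a 10-fold lower number from compound 3 to compound 4 (1.00 log units; beyond the scatter) and a 31-fold lower number from compound 1 to compound 4 (1.49 log units; beyond the scatter). Against pentyl, the same group gives a 1.1-fold higher number from compound 2 to compound 4 (0.04 log units; within the scatter), so a saturated chain is not needed to reach this level. No measurement here accounts for the change.

The compounds shown do not separate the effect of the branching from that of losing the methyl on the ring. From the compounds shown here alone, how an amine or a longer chain in this substituent would read also remains open.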